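This account rests on a few compounds, and the source may have more. Where it says the series, first, only, none or still open, it means among the compounds named here.

Compound 1, `C=CCn1c(=O)/c(=C\c2ccc(F)c(Br)c2)[nH]c(=O)/c1=C\c1ccccc1OC`: in a functional assay on BGC-823 cells (Homo sapiens) for cytotoxicity, read by CCK-8 assay, with a stated time of 72 h (a lower number here means a stronger inhibitor, a higher number a weaker inhibitor), compound 1 is reported as "not active" (no number reported).
Compound 2, `C=CCn1c(=O)/c(=C\c2ccccc2OC)[nH]c(=O)/c1=C\c1ccccc1OC`: in this assay compound 2 gives 13400 nM.

Within the data shown here, compound 2 is the one compound here with a measured number in this assay; compound 1 carries no number at all, only the report that it showed no activity. Compound 2 is therefore the only footing for any expectation about compound 3, `C=CCn1c(=O)/c(=C\c2ccc(C)cc2)[nH]c(=O)/c1=C\c1ccccc1OC`, which has not yet been measured.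

Compound 3 differs from compound 2 in one place: 4-methylphenyl in place of 2-methoxyphenyl on a double-bonded chain carbon bound to an aromatic carbon. The group that leaves and the group that enters are both single carbon rings, but the methoxy oxygen of compound 2 is gone in compound 3, and the methyl sits at a different position of the ring. Among the measured compounds shown here, with no measured step of this kind on hand, a small loss is expected, and compound 3 is estimated to sit within a 1.5-fold higher number from compound 2 to compound 3 (0.17 log units; within the scatter) of compound 2. For compound 3 the expected value is 20000 nM, with a range from 8000 nM to 60000 nM.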

Compound 3, half-maximal inhibitory concentration: "not active" (no number reported)
Nothing numeric was reported for compound 3; the estimate stays without a comparison.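

Among these compounds, compound 3 carries no number in this assay, and no step from compound 2 to compound 3 can be read. Nothing shown here bears on the reason for this result. The compounds shown leave open how far compound 3 lies from compound 2.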